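This account rests on a few compounds, and the source may have more. Where it says the series, first, only, none or still open, it means among the compounds named here.

Working notes on the series. Four compounds share one core; two have been measured in an assay on isolated protein for binding affinity to P-selectin (Homo sapiens), read by ELISA, tested at 500 uM; a lower number here means less inhibition, a higher number more inhibition at the concentration tested (going by the name of the read-out).

Compound 1 `CCCCCCCCCCOc1cc(OCCCCCCCCCC)cc(OCCCCCC(=O)N(c2ccc(C(=O)OC)cc2)c2ccc(C(=O)OC)cc2)c1` carries two methyl esters on the amide nitrogen and gives 16% in this assay. Compound 2 `CCCCCCCCCCOc1cc(OCCCCCCCCCC)cc(OCCCCCC(=O)N(c2ccc(C(=O)O)cc2)c2cccc(C(=O)O)c2)c1` carries the two free carboxylic acids instead and gives 58% in this assay. Compound 3 `CCCCCCCCCCOc1cc(OCCCCCCCCCC)cc(OCCCCCCN(Cc2ccc(C(=O)OC)cc2)c2ccc(C(=O)OC)cc2)c1`, with the amide carbonyl removed and one aryl group replaced by a benzyl group, is recorded in this assay as "not determined" (no result reported), so no number is available for it.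

On the two numbers at hand compound 2 stands highest; its nearest neighbour is compound 1, which is lower by a gap that lies beyond the usual scatter. Going by the values given here, no step between measured compounds has been worked out as a single change, so the series so far only shows that the two acid compound sits well above the two ester compound.

Compound 4 `CCCCCCCCCCOc1cc(OCCCCCCCCCC)cc(OCCCCCC(=O)N(Cc2ccc(C(=O)O)cc2)c2cccc(C(=O)O)c2)c1` is the next compound. It differs from compound 2 in one place: 4-carboxybenzyl in place of 4-carboxyphenyl on an amide-type nitrogen. Both acids are kept, so the change is confined to the inserted methylene on the amide nitrogen. Compound 2 is the only direct reference, and the step is expected to be small and within the scatter, perhaps slightly downward. The expected step from compound 2 to compound 4 in this assay is a number 8 percentage points lower from compound 2 to compound 4 (within the scatter). Compound 4 is estimated at 50%, in a range from 30% to 70%.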

Compound 4, a percentage reported as inhibition, at one concentration (the size of the read-out at that concentration, not a potency): 95%
Compound 4: middle estimate off by 45 percentage points, on the low side; measured number outside the range, above it.
By their numbers in this assay, from the lowest: compound 1; then compound 2; then compound 4.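

Going by these compounds alone, the change on the amide-type nitrogen is the first single change that can be read: with both acids kept, 4-carboxybenzyl in place of 4-carboxyphenyl gives a number 37 percentage points higher from compound 2 to compound 4 (beyond the scatter) in this assay. The two groups have the same aromatic ring, the same double bond outside it and the same hydrogen-bond donor and acceptor counts, and differ only in the carbon count, so this position responds strongly to a small change in the substituent, which the earlier gap between the two-ester and two-acid compounds could not show. Nothing available explains the size of this step.

On these data alone, it remains open whether a longer chain between the amide nitrogen and the carboxyphenyl ring, such as 4-carboxyphenethyl, would raise or lower the number in this assay, and whether the same step would appear with a different second aryl group on that nitrogen. Also unresolved is how much the carboxylic acid on the benzyl group contributes, which an unsubstituted benzyl group or a methyl ester at that place would test.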